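A few compounds are considered here, and "the series" means these few. Any claim that something is new, unique, unknown or untested is made for them only; others in the source may bear on it.

Going by the values given here, in a functional assay on PC-3 cells (Homo sapiens) (a lower number here means a stronger inhibitor of growth, a higher number a weaker inhibitor of growth), compound 2 `COc1ccccc1-c1cc(O)c2cccnc2n1` gives 29500 nM, the only actual number so far. Compound 1 `COc1ccccc1-c1cc(O)c2ccc(C)nc2n1` reads > 100000 nM, which is a limit of the assay and not a number. Among the compounds with values here, the one measured step is an at least 3.3-fold lower number from compound 1 to compound 2 (0.53 log units; beyond the scatter), and its size rests on (the limit of > 100000 nM in this assay, at which 1 of the 2 values shown sits).

Compound 3 `COc1ccccc1-c1cc(O)c2c(C)ccnc2n1` departs from compound 2 by methyl in place of hydrogen on an aromatic carbon, with methyl in place of hydrogen on an aromatic carbon, opposite the ring nitrogen. Within the data shown here, only that single step bears on this change, and it is an imperfect guide, since the methyl of compound 3 stands at a different carbon from that of compound 1. Even so, adding a methyl runs opposite to an at least 3.3-fold lower number from compound 1 to compound 2 (0.53 log units; beyond the scatter), so a modest move towards weaker growth inhibition is expected in this assay. The expected change is a 1.7-fold higher number from compound 2 to compound 3 (0.23 log units; within the scatter). Compound 3 is estimated at 50000 nM, within a range of 18000 nM to 100000 nM.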

Compound 3, concentration for 50% growth inhibition: 20900 nM
Beside the measured number, compound 3's estimate is 2.4-fold (0.38 log units) above it; low and high end bracket the measured number.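

In this assay, the methyl opposite the ring nitrogen gives a 1.4-fold lower number from compound 2 to compound 3 (0.15 log units; within the scatter), so at this position the group leaves growth inhibition where it was. Unlike the earlier step, this one has a real number at both ends, which fixes its size rather than only bounding it. Compound 1, with its methyl at a different carbon, reads > 100000 nM, which is a limit of the assay and not a number, so the earlier step gives only a bound: the limit of > 100000 nM in this assay, at which 1 of the 3 values shown sits.

The compounds shown leave open whether a larger or different group at this position, such as an ethyl chain, a chlorine or an amine, would move the number beyond the scatter. They also leave open how large the effect of the methyl in compound 1 really is.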